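A few compounds are considered here, and "the series" means these few. Any claim that something is new, unique, unknown or untested is made for them only; others in the source may bear on it.

Measured compounds in this series:

Compound 1 `COc1ccccc1/C=c1/[nH]c(=O)/c(=C\c2ccccc2OC)[nH]c1=O`: "not active" (no number reported)
Compound 2 `COc1ccccc1/C=c1\c(=O)[nH]/c(=C/c2cccc(Cl)c2Cl)c(=O)n1C`: 200 nM
Compound 3 `C=CCn1c(=O)/c(=C\c2cc(F)ccc2C)[nH]c(=O)/c1=C\c1ccccc1OC`: 4900 nM

All three compounds were tested in a functional assay on A549 cells (Homo sapiens) for cytotoxicity, read by CCK-8 assay, with a stated time of 72 h; on this read-out higher numbers stand for weaker inhibition and lower numbers for stronger inhibition. Compound 1 is reported as "not active" (no number reported), with no number attached. Compound 2 gives 200 nM, which is the lowest of the two numbers at hand and therefore the strongest inhibition measured so far. Compound 3 gives 4900 nM, a number that lies far above that of compound 2, well beyond the usual scatter of this kind of measurement. Since compound 2 and compound 3 differ in more than one place, the gap between them cannot be tied to a single change.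

Compound 4 `COc1ccccc1/C=c1\c(=O)[nH]/c(=C/c2ccccc2Cl)c(=O)n1C` has not been measured. Compared with compound 2, the change is hydrogen in place of chloro on an aromatic carbon. Only one chlorine atom leaves and nothing beyond a hydrogen enters, so the shared core and the methoxy-bearing ring stay as they are. With no single-change comparison available among the measured compounds, the step is expected to be modest, in the direction of weaker inhibition, as shown by a 2.5-fold higher number from compound 2 to compound 4 (0.40 log units; beyond the scatter). Compound 4 is therefore estimated at 500 nM in this assay, with a range from 150 nM to 2000 nM.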

Compound 4, half-maximal inhibitory concentration: 300 nM
The estimate for compound 4 lay 1.7-fold (0.22 log units) above the measured number, within the range that was stated.
By their numbers in this assay, from the lowest: compounds 2 and 4 (each within the scatter of the next); then compound 3.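

For the compounds shown here, this is the first comparison that isolates one place: going from 2,3-dichlorophenyl to 2-chlorophenyl, with hydrogen in place of chloro on an aromatic carbon, gives a 1.5-fold higher number from compound 2 to compound 4 (0.18 log units; within the scatter) in this assay. Compounds that differ by this one chloro, ortho to a chloro group, therefore cannot be told apart on this read-out, so at this position in this pair the second chlorine is not needed to reach the potency seen for compound 2. No measurement at hand bears on why the two compounds read alike.

A single exchange says little about this position in general, so an amine, a methoxy group or a carboxylic acid in place of the same chloro could behave quite differently, and the remaining chloro of compound 4 has no comparison of its own with plain hydrogen. Compound 1 and compound 3 differ from these two compounds in more than one place, so any steps to them cannot be read, and the separate contributions of the allyl group, the fluoro and methyl groups and the ring nitrogen substituents stay unresolved.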